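This account rests on a few compounds, and the source may have more. Where it says the series, first, only, none or still open, it means among the compounds named here.

Measured compounds:
- compound 1 `Nc1cc(Cc2ccn(Cc3cccc(Oc4ccccc4)c3)n2)c2nn[nH]c2n1`: 44 nM in an assay on isolated protein for inhibition of Myeloperoxidase (Homo sapiens), with a stated time of 10 min; a higher number here means a weaker inhibitor, a lower number a stronger inhibitor
- compound 2 `Nc1cc(Cc2ccn(Cc3cccc(Cc4ccccc4)c3)n2)c2nn[nH]c2n1`: 39 nM
- compound 3 `Nc1cc(Cc2ccn(Cc3cccc(Oc4cccc5c4CNC5)c3)n2)c2nn[nH]c2n1`: 26 nM

Compound 3 gives the lowest number of the three, but its distance to the others is small: a 1.7-fold lower number from compound 1 to compound 3 (0.23 log units; within the scatter) and a 1.5-fold lower number from compound 2 to compound 3 (0.18 log units; within the scatter), both within the scatter, as is a 1.1-fold lower number from compound 1 to compound 2 (0.05 log units; within the scatter). All three steps exchange one distal group for another on the shared core and none of them moves the number beyond the scatter.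

Compound 4 `Nc1cc(Cc2ccn(Cc3ccccc3)n2)c2nn[nH]c2n1` takes the change (a hydrogen atom in place of a group of 10 heavy atoms (8 carbon, 1 nitrogen, 1 oxygen; one five-membered non-aromatic ring with 1 hetero atom, one six-membered aromatic ring of carbon only), on an aromatic carbon), on an aromatic carbon of a six-membered aromatic ring of carbon only, meta to a large group. Within the data shown here, no measured step removes the whole group; the measured steps only replace it with another group of similar size, so they show that the kind of group carried there hardly matters, not what its absence does. The expectation is therefore uncertain: a modest loss is estimated, a 3.5-fold higher number from compound 3 to compound 4 (0.54 log units; beyond the scatter), with a wide range. Compound 4 is expected to give about 90 nM in this assay, between 25 nM and 350 nM.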

Compound 4, half-maximal inhibitory concentration: 120 nM
Compound 4: the middle estimate sits 1.3-fold (0.12 log units) below what was measured; low and high end bracket the measured number.
By their numbers in this assay, from the lowest: compounds 3, 2 and 1 (each within the scatter of the next); then compound 4.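

In this assay the loss of the whole group from this aromatic carbon appears as a 4.6-fold higher number from compound 3 to compound 4 (0.66 log units; beyond the scatter) and as a 3.1-fold higher number from compound 2 to compound 4 (0.49 log units; beyond the scatter) and as a 2.7-fold higher number from compound 1 to compound 4 (0.44 log units; beyond the scatter). All three steps are modest but lie beyond the scatter, unlike the exchanges among the larger groups, so carrying any of the three groups here is better than hydrogen, although compound 4 still gives 120 nM without one. Nothing available explains this loss.

From the compounds shown here alone, whether a small group at this carbon, such as methyl, methoxy or an amine, would already match the larger groups remains open. Also open, going by these compounds, is what a carboxylic acid or a longer chain would do here.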